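Swapping the Phenyl Terminus of a Catechol Vinyl Sulfone for Hexyl

The compounds below may be only part of what the source reports. "The series", "measured", "known", "first", "only" and "open" are said of these compounds alone.

The two measured compounds:
compound 1, `O=S(=O)(/C=C/c1ccc(O)c(O)c1)CCCc1ccccc1`, 11500 nM
compound 2, `O=S(=O)(/C=C/c1ccc(O)c(O)c1)CCCC1CCCCC1`, 7900 nM

Both were read in a functional assay, read by fluorescence and spectrophotometry, with a stated time of 1 h; on this read-out higher numbers stand for an effect only at larger amounts of compound and lower numbers for an effect already at smaller amounts. In this assay, among the measured compounds shown here, compound 1 gives 11500 nM and compound 2 gives 7900 nM; the two numbers lie within the scatter of each other, so compound 1 does not stand apart from its one neighbour. For the measured compounds named here, the single step between them, a 1.5-fold lower number from compound 1 to compound 2 (0.16 log units; within the scatter), is the only measured change at the chain end.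

The unmeasured compound 3 is `CCCCCCCCCS(=O)(=O)/C=C/c1ccc(O)c(O)c1`. It differs from compound 1 by hexyl in place of phenyl on a saturated chain carbon, three bonds along the chain from a sulfonyl sulfur. This change touches the same saturated chain carbon as the step to compound 2, which moved the number only within the scatter, so no step beyond the scatter is expected in this assay. Compound 3 is therefore estimated at 9500 nM, with a range from 4000 nM to 25000 nM, meaning an expected step of a 1.2-fold lower number from compound 1 to compound 3 (0.08 log units; within the scatter).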

Compound 3, half-maximal effective concentration: 7700 nM
Estimate against measurement, compound 3: 1.2-fold (0.09 log units) above; low and high end bracket the measured number.
By their numbers in this assay, from the lowest: compounds 3, 2 and 1 (each within the scatter of the next).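

In this assay, the position three bonds along the chain from the sulfonyl sulfur now also has an end group with no ring: hexyl in place of phenyl gives a 1.5-fold lower number from compound 1 to compound 3 (0.17 log units; within the scatter) and so, like the step to cyclohexyl, stays within the scatter. Hexyl in place of cyclohexyl gives a 1.0-fold lower number from compound 2 to compound 3 (0.01 log units; within the scatter), so compounds 1, 2 and 3, which carry an aromatic ring, a saturated ring and an open chain at this place, cannot be told apart on this read-out. Nothing at hand explains why the three read alike.

Going by these compounds, all three end groups contain carbon and hydrogen only, so it stays open how an amine or a carboxylic acid at the chain end would read. On these data alone, it also stays open whether a chain longer than hexyl would give a step beyond the scatter.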